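The source may hold more compounds than are shown below. What is called first, only, known or untested is meant among the compounds shown, and "the series" means these compounds.

Of the compounds shown here, two have so far been tested in a functional assay on the whole organism for inhibition, with Rattus norvegicus as the target, read by paw edema, at a dose of 100 mg/kg by the oral route; a lower number here means less inhibition, a higher number more inhibition at the dose given (going by the name of the read-out). Compound 1 `Cc1cccc(NC(=O)c2c(O)c3cccnc3n(-c3ccccc3)c2=O)c1` gives 14.2% in this assay, and compound 2 `O=C(Nc1cccc([N+](=O)[O-])c1)c1c(O)c2cccnc2n(-c2ccccc2)c1=O` gives 5.7%. Compound 2 holds the lower of the two numbers, yet the step of a number 8.5 percentage points lower from compound 1 to compound 2 (within the scatter) lies within the usual scatter of this kind of measurement, so on the numbers shown the two compounds cannot be told apart. Compound 3 `O=C(Nc1ccc(Cl)nc1)c1c(O)c2cccnc2n(-c2ccccc2)c1=O` keeps the shared core and differs from compound 2 only in the group carried on an amide-type nitrogen whose other neighbour is a carbonyl carbon: 6-chloropyridin-3-yl in place of 3-nitrophenyl on an amide-type nitrogen. Among the compounds with values here, the only measured step that bears on this change is a number 8.5 percentage points lower from compound 1 to compound 2 (within the scatter), where nitro took the place of methyl on an aromatic carbon, and it stayed within the scatter. With just this single step to go on, the change to compound 3 is expected to give a step of a number 4.3 percentage points higher from compound 2 to compound 3 (within the scatter), that is, nothing beyond the scatter in this assay. Compound 3 is therefore estimated at 10%, with a likely range from -5% to 25%.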

Compound 3, a percentage reported as inhibition, in the whole organism at one dose (the size of the read-out at that dose, not a potency): 9.2%
Estimate against measurement, compound 3: 0.8 percentage points above; measured number inside the range.
By their numbers in this assay, from the lowest: compounds 2, 3 and 1 (each within the scatter of the next).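

On the amide-type nitrogen of the shared core, a third group can now be compared in this assay: the step of a number 3.5 percentage points higher from compound 2 to compound 3 (within the scatter) and the step of a number 5 percentage points lower from compound 1 to compound 3 (within the scatter) both stay within the scatter. So at this position, 6-chloropyridin-3-yl cannot be told apart from either 3-nitrophenyl or 3-methylphenyl, even though this change replaces a ring of carbon only with a ring holding a hetero atom and swaps the nitro group for a chlorine. No measurement is available that would explain these numbers.

Going by these compounds, all three compounds carry a six-membered aromatic ring on the amide-type nitrogen, so it remains open whether any other kind of group at this position can shift the paw edema read-out beyond the scatter. A longer alkyl chain, a cyclohexyl ring or a phenyl ring bearing a carboxylic acid or an amine would test this, and only such a shift would show that this position matters for the effect at the dose given.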